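A few compounds are considered here, and "the series" means these few. Any claim that something is new, unique, unknown or untested is made for them only; others in the source may bear on it.

Compound 1 `CCC(c1ccccc1)c1cc(O)nc(SC(C)C)n1`: > 200000 nM (a limit)
Compound 2 `CCC(c1ccccc1)c1cc(O)nc(SC2CCCC2)n1`: 50000 nM
Compound 3 `CC(c1ccccc1)c1cc(O)nc(SC2CCCCC2)n1`: 149000 nM

In a functional assay on MT4 cells (Homo sapiens) for cytotoxicity (on this read-out higher numbers stand for lower toxicity in this test and lower numbers for higher toxicity in this test), compound 3 stands at 149000 nM. Compound 2 stands at 50000 nM. The gap between these two compounds lies beyond the scatter, and compound 3 has the higher number. The entry for compound 1 is a limit, not a number.

Compound 4 `CCC(c1ccccc1)c1cc(O)nc(SC2CCCCC2)n1` differs from compound 3 by methyl in place of hydrogen on a saturated chain carbon, two bonds along the chain from two aromatic carbons. For the measured compounds named here, no measured step makes this change. Going by the values given here, the only measured step, an at least 4.0-fold lower number from compound 1 to compound 2 (0.60 log units; beyond the scatter), lies on the sulfur instead and bears on it only loosely. A modest fall is expected, resting on compound 2 at 50000 nM. The expected size is a 2.1-fold lower number from compound 3 to compound 4 (0.33 log units; beyond the scatter). For compound 4 the estimate is 70000 nM, with an expected range of 25000 nM to 190000 nM.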

Compound 4, half-maximal cytotoxic concentration: 51000 nM
Compound 4: the middle estimate sits 1.4-fold (0.14 log units) above what was measured; the measured number falls inside the stated range.
By their numbers in this assay, from the lowest: compounds 2 and 4 (each within the scatter of the next); then compound 3. At a limit, above all of these: compound 1.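

In this assay, for the compounds shown here, methyl in place of hydrogen on a saturated chain carbon, two bonds along the chain from two aromatic carbons, gives the first reading at this position: a 2.9-fold lower number from compound 3 to compound 4 (0.47 log units; beyond the scatter). With that ethyl in place, cyclohexyl instead of cyclopentyl on the sulfur gives a 1.0-fold higher number from compound 2 to compound 4 (0.01 log units; within the scatter). Cyclohexyl instead of isopropyl gives an at least 3.9-fold lower number from compound 1 to compound 4 (0.59 log units; beyond the scatter), a step read against a limit and not a number.

From the compounds shown here alone, it remains open whether a longer chain, a hydroxyl or an amine on this carbon would shift the number further, and whether the methyl step holds with other groups on the sulfur.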